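The source may hold more compounds than are shown below. What is called first, only, known or untested is meant among the compounds shown, and "the series" means these compounds.

Of the compounds shown here, two have been measured in an assay on membranes from brain (Cavia porcellus) for binding affinity to Sigma non-opioid intracellular receptor 1 (Homo sapiens), read by radioligand binding; on this read-out higher numbers stand for weaker inhibition and lower numbers for stronger inhibition. Compound 1 `O=C(Cc1c[nH]c2ccccc12)NC1CCN(Cc2ccccc2)CC1` gives 10.9 nM in this assay. Compound 2 `O=C(Cc1c[nH]c2ccc(Br)cc12)NC1CCN(Cc2ccccc2)CC1`, which carries bromo in place of hydrogen on an aromatic carbon, gives 51.9 nM in this assay. The step of a 4.8-fold higher number from compound 1 to compound 2 (0.68 log units; beyond the scatter) lies beyond the scatter, so compound 2 stands with the highest of the two numbers shown, and its nearest neighbour is compound 1 with the lower number.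

The next compound, compound 3 `COc1ccc2[nH]cc(CC(=O)NC3CCN(Cc4ccccc4)CC3)c2c1`, differs from compound 2 in one place: methoxy in place of bromo on an aromatic carbon. Among the measured compounds shown here, only one measured step touches this position, namely a 4.8-fold higher number from compound 1 to compound 2 (0.68 log units; beyond the scatter), which shows what exchanging hydrogen for bromo there did to the number. For the measured compounds named here, a methoxy at the same aromatic carbon has no measured counterpart, and nothing among the two measured compounds shows whether it behaves more like bromo or more like hydrogen. The expectation for compound 3 is therefore placed between the two measured numbers, with a step of a 2.1-fold lower number from compound 2 to compound 3 (0.32 log units; beyond the scatter) expected in this assay toward a lower number. Compound 3 is estimated at 25 nM, within a range from 8 nM to 80 nM.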

Compound 3, inhibition constant: 125 nM
The estimate for compound 3 lay 5.0-fold (0.70 log units) below the measured number; measured number above the stated range.
By their numbers in this assay, from the lowest: compound 1; then compound 2; then compound 3.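

In this assay, among the compounds shown here, methoxy in place of hydrogen on this aromatic carbon gives an 11-fold higher number from compound 1 to compound 3 (1.06 log units; beyond the scatter), so bromo is no longer the only group there that goes with a higher number than hydrogen. Methoxy also does not fall in the span set by hydrogen and bromo: a 2.4-fold higher number from compound 2 to compound 3 (0.38 log units; beyond the scatter) carries the number past that of bromo, and the order at this position, from the lowest number, runs hydrogen, bromo, methoxy, with every step beyond the scatter. Nothing available accounts for why methoxy stands above bromo here.

With only hydrogen, bromo and methoxy shown at this carbon, it stays open whether any other group, such as fluoro, hydroxy, an amine or a carboxylic acid, would give a number near that of hydrogen or would also give a higher one. Going by these compounds, it also stays open whether bromo and methoxy would keep this order on another aromatic carbon of the shared core, or whether a longer chain on the oxygen of the methoxy would move the number further.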